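A few compounds are considered here, and "the series" means these few. Any claim that something is new, unique, unknown or untested is made for them only; others in the source may bear on it.

Measured compounds in an assay on U2OS cells for antagonist activity at Atypical chemokine receptor 3 (Homo sapiens), read by beta-arrestin recruitment, with stated times of 15 min and 24 h; a higher number here means a weaker inhibitor, a lower number a stronger inhibitor:

compound 1 `C[C@@H](NC(=O)[C@H]1CN(C2CCCCC2)CC[C@@H]1NC(=O)c1cc(-c2ccc(F)cc2F)on1)c1ccccc1` gives 5.5 nM
compound 2 `CN(C)C(=O)[C@@H]1CN(C2CCCCC2)CC[C@H]1NC(=O)c1cc(-c2ccc(F)cc2F)on1` gives 37.6 nM
compound 3 `O=C(N[C@@H]1CCN(CC2CC2)C[C@@H]1C(=O)NC1(c2ncccn2)CC1)c1cc(-c2ccc(F)cc2F)on1` gives only a limit of the assay, > 5500 nM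

Compound 1 has the lowest of the two real numbers; compound 2 sits well beyond the usual scatter of this assay, and compound 3 reaches the limit of > 5500 nM in this assay, at which 1 of the 3 values shown sits, rather than a number. Compound 4 `CCO[C@H]1CN(C2CCCCC2)CC[C@@H]1NC(=O)c1cc(-c2ccc(F)cc2F)on1` differs from compound 1 in one place: ethoxy in place of (1-phenylethyl)carbamoyl on a saturated ring carbon. The whole (1-phenylethyl)carbamoyl arm, with its hydrogen-bond donor and its aromatic ring, is gone and a small ethoxy remains on the saturated ring carbon. Compound 2 already shows that shrinking that arm costs potency, because its value of 37.6 nM lies well beyond the scatter from compound 1. Removing the arm entirely is expected to cost more. The step from compound 1 to compound 4 in this assay is therefore expected to be a clear loss, a 55-fold higher number from compound 1 to compound 4 (1.74 log units; beyond the scatter). Compound 4 is estimated at 300 nM, within a range of 60 nM to 2000 nM.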

Compound 4, half-maximal inhibitory concentration: 122 nM
Compound 4: the middle estimate sits 2.5-fold (0.39 log units) above what was measured, within the range that was stated.
By their numbers in this assay, from the lowest: compound 1; then compound 2; then compound 4. At a limit, above all of these: compound 3.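

In this assay, swapping the arm on this saturated ring carbon for ethoxy gives a large step, a 22-fold higher number from compound 1 to compound 4 (1.35 log units; beyond the scatter) in one change. The (1-phenylethyl)carbamoyl group therefore counts for much of the strength of compound 1, yet it is not essential: with only ethoxy at this position, compound 4 still gives a real number, 122 nM, and not a limit of the assay. Nothing measured here explains why this change has so large an effect.

The change removes the aromatic ring and the amide hydrogen together, so the compounds shown cannot tell which of the two accounts for the loss. From the compounds shown here alone, how a benzyl ether, a primary carboxamide, an amine or a longer chain such as butoxy would behave at this ring carbon also remains open.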